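The source may report more compounds than this note shows. Statements on the series, on what has been measured and on what is new or still open speak of the compounds shown alone.

Measured so far: compound 1 `CCCCCCCCCCCCCCNC(=O)[C@@H](N)[C@@H](C)O`, 18700 nM; compound 2 `CCCCCCCCCCCCCCCCCCNC(=O)[C@@H](N)[C@@H](C)O`, 21400 nM; compound 3 `CCCCCCCCCCCCCCNC(=O)[C@@H](NC(=O)c1cccs1)[C@@H](C)O`, 78400 nM.

All three were tested in a functional assay on SW-620 cells (Homo sapiens) for cytotoxicity, read by MTT assay, with a stated time of 48 h; on this read-out lower numbers stand for stronger inhibition and higher numbers for weaker inhibition. Compound 2 has the second highest of the three numbers; its value and that of compound 1 lie within the scatter of each other, while compound 3 lies beyond the scatter above both. Compound 4 `CCCCCCCCCCCCCCCCCCNC(=O)[C@@H](NC(=O)c1cc2ccccc2[nH]1)[C@@H](C)O` has not yet been measured. The change is (1H-indol-2-yl)carbonyl in place of hydrogen on an amine nitrogen. The comparable measured step is a 4.2-fold higher number from compound 1 to compound 3 (0.62 log units; beyond the scatter), where a group was likewise put in place of hydrogen on an amine nitrogen. The other step, a 1.1-fold higher number from compound 1 to compound 2 (0.06 log units; within the scatter), touches only the chain and stays within the scatter. A similar modest rise in the number, meaning weaker inhibition, is therefore expected in this assay. Compound 4 is estimated at 65000 nM, within 28000 nM to 160000 nM, the expected step being a 3.0-fold higher number from compound 2 to compound 4 (0.48 log units; beyond the scatter).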

Compound 4, half-maximal inhibitory concentration: 23600 nM
Compound 4: the middle estimate sits 2.8-fold (0.44 log units) above what was measured; measured number outside the range, below it.
By their numbers in this assay, from the lowest: compounds 1, 2 and 4 (each within the scatter of the next); then compound 3.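

On this amine nitrogen, replacing hydrogen with a larger group need not raise the number in this assay: (1H-indol-2-yl)carbonyl gives a 1.1-fold higher number from compound 2 to compound 4 (0.04 log units; within the scatter), whereas (thiophen-2-yl)carbonyl gave a 4.2-fold higher number from compound 1 to compound 3 (0.62 log units; beyond the scatter). The penalty seen earlier therefore does not hold for every group placed there, although these two steps also start from compounds with different chains. Nothing available explains the contrast between them.

Still open, on these data alone, is whether (1H-indol-2-yl)carbonyl would behave the same way on the shorter chain of compound 1. As far as these compounds go, how a benzoyl or acetyl group would read on this nitrogen also remains open.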